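The source may report more compounds than this note shows. Statements on the series, on what has been measured and on what is new or still open speak of the compounds shown alone.

Of the compounds shown here, three with a shared core have been measured in an assay for inhibition of Tryptophan 2,3-dioxygenase (Homo sapiens), with stated times of 10 min and 60 min; a higher number here means a weaker inhibitor, a lower number a stronger inhibitor. Compound 1 `FC(F)(F)c1cc(NC[C@H]2CCCN2)c2cn[nH]c2c1` gives 6090 nM, compound 2 `O=[N+]([O-])c1cccc(CNc2cc(C(F)(F)F)cc3[nH]ncc23)c1` gives 5170 nM, and compound 3 `FC(F)(F)c1cc(NC[C@@H]2CCCCN2)c2cn[nH]c2c1` gives 8050 nM. In this assay compound 3 has the highest of the three numbers, yet its gaps to the other two stay within the scatter: the step of a 1.3-fold higher number from compound 1 to compound 3 (0.12 log units; within the scatter) is small, and compound 2 also lies within the scatter of compound 3. Compound 4 `FC(F)(F)c1cc(NCc2cccc(Br)c2)c2cn[nH]c2c1` has not yet been measured in this assay. It differs from compound 3 as follows: 3-bromophenyl in place of piperidin-2-yl on a saturated chain carbon bound to a nitrogen on an aromatic ring. Going by the values given here, no measured step covers exactly this exchange. Among the compounds with values here, the only step at the same place, a 1.3-fold higher number from compound 1 to compound 3 (0.12 log units; within the scatter), swapped one saturated ring for another and stayed within the scatter. Compound 2 carries a different group at that same place, and its value in this assay sits within the scatter of compound 3. The expected step of a 1.6-fold lower number from compound 3 to compound 4 (0.21 log units; within the scatter) is therefore small, with no clear direction. Compound 4 is estimated at 5000 nM, with a range from 2000 nM to 12500 nM.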

Compound 4, half-maximal inhibitory concentration: 19100 nM
Compound 4: middle estimate off by 3.8-fold (0.58 log units), on the low side, outside the stated range (above it).
By their numbers in this assay, from the lowest: compounds 2, 1 and 3 (each within the scatter of the next); then compound 4.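

In this assay the exchange at this position, on a saturated chain carbon bound to a nitrogen on an aromatic ring, now has an effect beyond the scatter: 3-bromophenyl gives a 2.4-fold higher number from compound 3 to compound 4 (0.38 log units; beyond the scatter) against the piperidin-2-yl group and a 3.1-fold higher number from compound 1 to compound 4 (0.50 log units; beyond the scatter) against the pyrrolidin-2-yl group. So this place is not indifferent to what it carries, although the swap between the two saturated rings gave no clear change. An aromatic ring alone does not fix the number, since bromo in place of nitro on an aromatic carbon gives a 3.7-fold higher number from compound 2 to compound 4 (0.57 log units; beyond the scatter) and thus shows that the group on that ring counts too.

Nothing available gives a reason for these steps. Still open, as far as these compounds go, is how an unsubstituted phenyl ring, or a phenyl ring carrying an amine or a carboxylic acid in place of the bromo, would behave in this assay.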